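The compounds below may be only part of what the source reports. "The series", "measured", "known", "first", "only" and "open" are said of these compounds alone.

Compound 1 `COc1ccc2nc(C)cc(OCC(=O)Nc3cc(C)cc(C)c3)c2c1` gives 26000 nM in a physicochemical assay for solubility, in phosphate buffer, measured as kinetic solubility, with a stated time of 1 h, at pH 7.4 (a lower number here means a less soluble compound, a higher number a more soluble compound), the lowest of the three numbers in hand, though compound 2 `Cc1cc(C)cc(NC(=O)COc2cc(C)nc3ccc(F)cc23)c1` with 28000 nM sits within the scatter of it, while compound 3 `CCC(Oc1cc(C)nc2ccc(OC)cc12)C(=O)Nc1cc(C)cc(C)c1` with 123000 nM lies further off. The two measured steps are a 1.1-fold higher number from compound 1 to compound 2 (0.03 log units; within the scatter) and a 4.7-fold higher number from compound 1 to compound 3 (0.67 log units; beyond the scatter). Compound 4 `COc1ccc2nc(C)cc(OCC(=O)Nc3ccc(Cl)c(OC)c3)c2c1` differs from compound 1 by 4-chloro-3-methoxyphenyl in place of 3,5-dimethylphenyl on an amide-type nitrogen. Among the compounds with values here, neither measured step alters that ring, so no direct precedent exists; the nearest parallel is the swap of one aromatic substituent for another in a 1.1-fold higher number from compound 1 to compound 2 (0.03 log units; within the scatter), which stayed within the scatter. For compound 4 the account therefore expects a 1.2-fold higher number from compound 1 to compound 4 (0.06 log units; within the scatter), and estimates its value in this assay at 30000 nM, within a range of 12000 nM to 75000 nM.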

Compound 4, solubility: 13000 nM
Estimate against measurement, compound 4: 2.3-fold (0.36 log units) above, and the stated range covers the measured number.
By their numbers in this assay, from the lowest: compounds 4, 1 and 2 (each within the scatter of the next, the first and the last beyond it); then compound 3.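

The first change shown at the amide-type nitrogen, 4-chloro-3-methoxyphenyl in place of 3,5-dimethylphenyl, gives a 2.0-fold lower number from compound 1 to compound 4 (0.30 log units; within the scatter) in this assay. This aromatic group could therefore be exchanged, with one more hydrogen-bond acceptor by count, without a step beyond the scatter, although only this one replacement is shown at this position. The compounds shown leave open how chloro alone or methoxy alone on this ring would read, and how an amine or a carboxylic acid there would read. No supporting measurement bears on the reason for this step.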